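Taking the chloro group off compound 1

The source may report more compounds than this note shows. Statements on the series, on what has been measured and on what is new or still open speak of the compounds shown alone.

Going by the values given here, in a functional assay on SiHa cells (Homo sapiens) for inhibition, read by CCK-8 assay, with a stated time of 72 h, tested at 10 uM (on this read-out lower numbers stand for less inhibition of growth and higher numbers for more inhibition of growth at the one concentration tested), compound 1 (`CN(C)C(=O)c1cc2cnc(Nc3ccc(NC(=O)C4(C(=O)Nc5cccc(Cl)c5)CC4)cc3)nc2n1C1CCCC1`) gives 97.3% and stands highest of the two numbers so far. Compound 2 (`CN(C)C(=O)c1cc2cnc(Nc3ccc(NC(=O)C4(C(=O)Nc5ccc(F)cc5)CC4)cc3F)nc2n1C1CCCC1`) gives 44.4% there, a gap beyond the usual scatter. Compound 3 (`CN(C)C(=O)c1cc2cnc(Nc3ccc(NC(=O)C4(C(=O)Nc5ccccc5)CC4)cc3)nc2n1C1CCCC1`) carries hydrogen in place of chloro on an aromatic carbon, so 3-chlorophenyl becomes phenyl. Among the compounds with values here, no measured pair shows this change alone, which leaves the forecast resting on little evidence. With compound 1 at 97.3% there is small room upward, so any move is expected to be downward. The expected step is a number 17.3 percentage points lower from compound 1 to compound 3 (beyond the scatter) and it would probably lie beyond the scatter, though a step within it remains possible. Compound 3 is estimated at 80% with an expected range from 50% to 99% once it is measured.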

Compound 3, percent growth inhibition at one concentration: 106%
The estimate for compound 3 lay 26 percentage points below the measured number, outside the stated range (above it).
By their numbers in this assay, from the lowest: compound 2; then compounds 1 and 3 (each within the scatter of the next).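

In this assay, hydrogen in place of chloro on this six-membered aromatic ring gives a number 8.7 percentage points higher from compound 1 to compound 3 (within the scatter), so compound 1 and compound 3 cannot be told apart on this read-out. At this one concentration, the chloro group is therefore not needed for the high growth inhibition seen with compound 1, and the plain phenyl group serves as well as 3-chlorophenyl. Nothing measured here offers an explanation for this result.

From the compounds shown here alone, whether compound 1 and compound 3 would separate at lower concentrations remains open, since a single concentration gives no measure of potency. Also open, going by these compounds, is how a larger or differently charged group in the same place, such as a methoxy group, an amine or a carboxylic acid, would fare.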